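This account rests on a few compounds, and the source may have more. Where it says the series, first, only, none or still open, it means among the compounds named here.

Working notes on the series. Two compounds have been run so far, sharing one core. Compound 1 is `Cc1cnc(Nc2ccc(C#N)cc2)nc1Oc1ccc2cc(C#N)ccc2c1` and compound 2 is `Cc1cc(Oc2ccc3cc(C#N)ccc3c2)nc(Nc2ccc(C#N)cc2)n1`. In an ADME assay on MT4 cells (Homo sapiens) for cytotoxicity, read by MTT assay, with a stated time of 4 days (on this read-out lower numbers stand for higher toxicity in this test and higher numbers for lower toxicity in this test), compound 1 gives > 331000 nM, which is a limit of the assay rather than a number. In this assay compound 2 gives > 331000 nM, again a limit and not a number. For the measured compounds named here, both values shown sit at the limit of > 331000 nM in this assay, at which 2 of the 2 values shown sit, so no step between measured compounds can be sized, and compound 2 cannot be ranked against compound 1; each simply failed to reach a half-maximal effect within the concentrations tested.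

Compound 3 is `Cc1cc(Oc2ccc3cc(C#N)ccc3c2Br)nc(Nc2ccc(C#N)cc2)n1`. It differs from compound 2 by bromo in place of hydrogen on an aromatic carbon. Going by the values given here, no measured step covers this kind of change. Among the compounds with values here, with every value so far resting at the limit of > 331000 nM in this assay, at which 2 of the 2 values shown sit, the step expected in this assay is an at least 1.1-fold lower number from compound 2 to compound 3 (0.04 log units; that floor lies within the scatter), nothing beyond the scatter and most probably another limit. Compound 3 is accordingly expected to give 300000 nM, with a range from 100000 nM to 1000000 nM.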

Compound 3, half-maximal cytotoxic concentration: > 274000 nM
Compound 3 was reported as a limit (the forecaster's own chance of this, stated with the estimate: 80%); the middle value lies beyond the limit too.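

In this assay compound 3 gives > 274000 nM, a limit and not a number. For the compounds shown here, compound 2 also rests at a limit, so no step from compound 2 to compound 3 can be read. The compounds shown leave open whether bromo in place of hydrogen on an aromatic carbon changes this read-out at all, and at what concentration any of the three compounds would reach a half-maximal effect.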